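From isobutyl to methyl on a shared core

The source may hold more compounds than are shown below. What is called first, only, known or untested is meant among the compounds shown, and "the series" means these compounds.

- compound 1 (`COc1c(C)cnc(CN2c3nc(N)nc(Cl)c3NC(=O)[C@@H]2CC(C)C)c1C`) at 930 nM
- compound 2 (`COc1c(C)cnc(CN2CC(=O)N(CCN3CCCC3)c3c(Cl)nc(N)nc32)c1C`) at 1320 nM

Both values come from a functional assay on MCF7 cells (Homo sapiens) for inhibition (a lower number here means a stronger inhibitor, a higher number a weaker inhibitor), and lie within the scatter of each other, so compound 1 stands level with compound 2. Among the measured compounds shown here, the two differ in more than one place, so no measured step guides what follows. Compound 3 (`COc1c(C)cnc(CN2c3nc(N)nc(Cl)c3NC(=O)[C@@H]2C)c1C`) shortens the side chain of compound 1 from isobutyl to methyl (hydrogen in place of isopropyl on a saturated chain carbon bound to a saturated ring carbon), with hydrogen in place of isopropyl on a saturated chain carbon bound to a saturated ring carbon. Compound 2 carries no isobutyl group and still gives 1320 nM so a collapse is not expected. In this assay a modest step toward a higher number is expected, possibly no larger than the scatter. The estimated change is a 1.6-fold higher number from compound 1 to compound 3 (0.21 log units; within the scatter) in that direction. For compound 3 the expected value is 1500 nM (estimated range 500 nM to 4500 nM).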

Compound 3, half-maximal inhibitory concentration: 940 nM
Compound 3: the middle estimate sits 1.6-fold (0.20 log units) above what was measured; measured number inside the range.
By their numbers in this assay, from the lowest: compounds 1, 3 and 2 (each within the scatter of the next).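

In this assay, the step of a 1.0-fold higher number from compound 1 to compound 3 (0.00 log units; within the scatter) comes with shortening the side chain from isobutyl to methyl, and it is the only single-place comparison among the compounds shown. On the shared core, the isopropyl part of that chain, on a saturated chain carbon bound to a saturated ring carbon, can therefore give way to hydrogen with the values staying within the scatter, something compound 2, which differs from compound 1 in more than one place, could not show. Nothing measured here gives a reason for this result. On these data alone, it remains open how this position responds to a different kind of group in place of the methyl of compound 3, such as an amine, a carboxylic acid or a phenyl ring. As far as these compounds go, a chain longer than isobutyl also remains open.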